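This account rests on a few compounds, and the source may have more. Where it says the series, first, only, none or still open, it means among the compounds named here.

Values in a physicochemical assay for solubility, read by spectrophotometry, measured as kinetic solubility, at pH 8, tested at 500 uM; a higher number here means a more soluble compound, a lower number a less soluble compound:
- compound 1 `Cn1cc(CNC(=O)c2ccncc2Nc2cc(-c3ccc4ccn(C)c4c3)c3nccnc3c2)cn1`: 127 ug/mL
- compound 2 `CN1CC(NC(=O)c2ccncc2Nc2cc(-c3ccc4ccn(C)c4c3)c3nccnc3c2)CCC1=O`: 253 ug/mL
- compound 3 `Cn1ccc2ccc(-c3cc(Nc4cnccc4C(=O)NCC4COCCN4)cc4nccnc34)cc21`: 239 ug/mL

All three values lie within the scatter of one another, so compound 3 at 239 ug/mL stands apart from neither neighbour.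

Next is compound 4 `CN1CC(NC(=O)c2ccncc2Nc2cc(-c3ccc4ccn(C)c4c3)c3nccnc3c2)C1`, with 1-methylazetidin-3-yl in place of (morpholin-3-yl)methyl on an amide-type nitrogen.

Three measured steps exchange the group at this nitrogen: a 2.0-fold higher number from compound 1 to compound 2 (0.30 log units; within the scatter), a 1.9-fold higher number from compound 1 to compound 3 (0.27 log units; within the scatter) and a 1.1-fold lower number from compound 2 to compound 3 (0.02 log units; within the scatter). All stay within the scatter, so no step beyond the scatter is expected in this assay. The expected step is a 1.1-fold lower number from compound 3 to compound 4 (0.04 log units; within the scatter). For compound 4 the estimated value is 220 ug/mL, with an expected range of 125 ug/mL to 280 ug/mL.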

Compound 4, solubility: 170 ug/mL
Estimate against measurement, compound 4: 1.3-fold (0.11 log units) above; low and high end bracket the measured number.
By their numbers in this assay, from the lowest: compounds 1, 4, 3 and 2 (each within the scatter of the next).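

In this assay the exchange to 1-methylazetidin-3-yl on the amide-type nitrogen gives a 1.4-fold lower number from compound 3 to compound 4 (0.15 log units; within the scatter) and a 1.5-fold lower number from compound 2 to compound 4 (0.17 log units; within the scatter) and also a 1.3-fold higher number from compound 1 to compound 4 (0.13 log units; within the scatter) with all three inside the scatter. Four groups at this nitrogen, from the four-membered ring of compound 4 to the six-membered ring of compound 3, now show no step beyond the scatter, so ring size among these compounds has no separable link to the number. Nothing at hand accounts for the result.

Still open, from the compounds shown here alone, is whether a carboxylic acid or an open-chain dimethylamino group at this nitrogen would give a step beyond the scatter.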